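Moving a Double Bond in the Side Chain of Compound 2

This account rests on a few compounds, and the source may have more. Where it says the series, first, only, none or still open, it means among the compounds named here.

Compound 1 `COC(=O)CC/C=C\CC[C@H]1C(=O)C[C@@H](O)[C@@H]1/C=C/C[C@@](C)(O)C#CC1=CCCC1`: > 3.16 mg/kg (a limit, not a number)
Compound 2 `COC(=O)CC/C=C\CC[C@H]1C(=O)C[C@@H](O)[C@@H]1/C=C/C[C@@](C)(O)/C=C/C1CCCC1`: 1.95 mg/kg

Within the data shown here, in a functional assay on the whole organism with Rattus norvegicus as the target (on this read-out lower numbers stand for an effect already at smaller amounts and higher numbers for an effect only at larger amounts of compound), compound 2 gives 1.95 mg/kg, the only actual number so far. Compound 3 `COC(=O)CC/C=C\CC[C@H]1C(=O)C[C@@H](O)[C@@H]1/C=C/CC(C)(O)CCC1=CCCC1` has the same atoms as compound 2, joined differently: 3-(cyclopent-1-en-1-yl)-1-hydroxy-1-methylpropyl in place of 3-cyclopentyl-1-hydroxy-1-methylprop-2-en-1-yl on a saturated chain carbon bound to a double-bonded chain carbon. Among the measured compounds shown here, the one measured step, an at least 1.6-fold lower number from compound 1 to compound 2 (0.20 log units; that floor lies within the scatter), changes the same part of the molecule, but it rests on a limit and offers only weak guidance. The expected step is a 1.4-fold higher number from compound 2 to compound 3 (0.16 log units; within the scatter), toward a slightly higher number, with no change expected beyond the scatter. For compound 3 the estimated value is 2.8 mg/kg, with an expected range from 0.9 mg/kg to 9 mg/kg.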

Compound 3, dose for half-maximal effect: 1.18 mg/kg
Estimate against measurement, compound 3: 2.4-fold (0.38 log units) above; measured number inside the range.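

Shifting the double bond into the ring at this place, on a saturated chain carbon bound to a double-bonded chain carbon, gives a 1.7-fold lower number from compound 2 to compound 3 (0.22 log units; within the scatter) in this assay. Among these compounds, replacing the triple-bonded chain of compound 1 with the saturated chain gives an at least 2.6-fold lower number from compound 1 to compound 3 (0.42 log units; beyond the scatter), the first step here that clears the scatter. That step starts from a limit, not a number: the limit of > 3.16 mg/kg in this assay, at which 1 of the 3 values shown sits.

The compounds shown leave open how a phenyl ring or a longer chain in place of the cyclopent-1-en-1-yl ring would fare.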